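The compounds below may be only part of what the source reports. "The series", "measured", "known", "first", "only" and "open" are said of these compounds alone.

Among the compounds with values here, compound 1 `O=C(CSc1nnc(-c2ccncc2)o1)N/N=C/c1ccccc1` gives 22100 nM in a functional assay on BGC-823 cells (Homo sapiens) for cytotoxicity, read by MTT assay, with a stated time of 48 h (a higher number here means a weaker inhibitor, a lower number a stronger inhibitor), the second highest of the three numbers measured so far; its nearest neighbour is compound 2 `O=C(CSc1nnc(-c2ccncc2)o1)N/N=C/c1ccc(F)cc1` at 17800 nM, and compound 3 `O=C(CSc1nnc(-c2ccncc2)o1)N/N=C/c1ccc([N+](=O)[O-])cc1` lies furthest at 31500 nM. Every step among these three stays within the scatter: a 1.2-fold lower number from compound 1 to compound 2 (0.09 log units; within the scatter), a 1.4-fold higher number from compound 1 to compound 3 (0.15 log units; within the scatter) and a 1.8-fold higher number from compound 2 to compound 3 (0.25 log units; within the scatter). Compound 4 `O=C(CSc1nnc(-c2ccncc2)o1)N/N=C/c1ccccc1O` carries the change (hydroxy in place of hydrogen on an aromatic carbon). Within the data shown here, the steps that bear on it are the two substitutions on an aromatic carbon of the same ring, fluoro and nitro in place of hydrogen, and neither moved the number beyond the scatter. Among the measured compounds shown here, a hydroxy group has no direct precedent in this set, and its position, ortho to a large group, differs from the other substitutions, so the comparison is loose; still, nothing measured points to a real step in either direction. Compound 4 is therefore expected to give about 22000 nM in this assay, within 9000 nM to 55000 nM. The expected step from compound 1 is a 1.0-fold lower number from compound 1 to compound 4 (0.00 log units; within the scatter), none beyond the scatter.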

Compound 4, half-maximal inhibitory concentration: 6160 nM
For compound 4 the middle estimate is 3.6-fold (0.55 log units) above the measured one; the measured number lies below the stated range.
By their numbers in this assay, from the lowest: compound 4; then compounds 2, 1 and 3 (each within the scatter of the next).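

In this assay, within the data shown here, hydroxy on an aromatic carbon ortho to a large group is the first change on this ring to go beyond the scatter, with a 3.6-fold lower number from compound 1 to compound 4 (0.55 log units; beyond the scatter). The 2-hydroxyphenyl compound also stands apart from both substituted analogues, with a 2.9-fold lower number from compound 2 to compound 4 (0.46 log units; beyond the scatter) and a 5.1-fold lower number from compound 3 to compound 4 (0.71 log units; beyond the scatter), whereas 4-fluorophenyl and 4-nitrophenyl stayed within the scatter of phenyl and of each other. No measurement at hand accounts for this step.

On these data alone, it remains open whether the step belongs to hydroxy itself or to its place on the ring, as the fluoro and nitro groups stand elsewhere in compound 2 and compound 3. Also open, as far as these compounds go, is whether a methoxy group or an amine at the place of the hydroxy would give a number close to that of compound 4.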